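Swapping the amine substituent in a chemokine receptor antagonist series

A few compounds are considered here, and "the series" means these few. Any claim that something is new, unique, unknown or untested is made for them only; others in the source may bear on it.

Compound 2 `CC1(C)CCC(NCc2ccc(CN(C[C@H]3Cc4ccccc4CN3)[C@H]3CCCc4cccnc43)cc2)CC1` gives 661 nM in a functional assay on cells for antagonist activity at C-X-C chemokine receptor type 4 (Homo sapiens), read by fluorescence and calcium flux, with stated times of 25 min and 90 s (a higher number here means a weaker inhibitor, a lower number a stronger inhibitor), the higher of the two numbers in hand; its nearest neighbour is compound 1 `c1ccc2c(c1)CN[C@@H](CN(Cc1ccc(CNC3CCOCC3)cc1)[C@H]1CCCc3cccnc31)C2`, which in this assay gives 90.3 nM. Compound 3 `c1ccc(CNCc2ccc(CN(C[C@H]3Cc4ccccc4CN3)[C@H]3CCCc4cccnc43)cc2)nc1` carries (pyridin-2-yl)methyl in place of 4,4-dimethylcyclohexyl on an amine nitrogen. Among the measured compounds shown here, the one step that bears on this exchange is a 7.3-fold higher number from compound 1 to compound 2 (0.86 log units; beyond the scatter), where the 4,4-dimethylcyclohexyl group entered. Its removal is therefore expected to bring the number down, with a step of about a 4.4-fold lower number from compound 2 to compound 3 (0.64 log units; beyond the scatter) in this assay anticipated. Compound 3 is estimated at 150 nM, within a range of 40 nM to 550 nM.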

Compound 3, half-maximal inhibitory concentration: 286 nM
The estimate for compound 3 lay 1.9-fold (0.28 log units) below the measured number; low and high end bracket the measured number.
By their numbers in this assay, from the lowest: compound 1; then compound 3; then compound 2.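

In this assay the exchange of 4,4-dimethylcyclohexyl for (pyridin-2-yl)methyl on this amine nitrogen brings a 2.3-fold lower number from compound 2 to compound 3 (0.36 log units; beyond the scatter) and so wins back only part of the earlier loss. Set against oxan-4-yl, the same group gives a 3.2-fold higher number from compound 1 to compound 3 (0.50 log units; beyond the scatter) and oxan-4-yl therefore keeps the lowest number of the three groups. Nothing in hand explains this order.

From the compounds shown here alone, how a plain benzyl or a piperidin-4-yl group on this nitrogen would rank remains open. So does whether the ring nitrogen of (pyridin-2-yl)methyl contributes to the step at all.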